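The source may hold more compounds than are shown below. What is called first, only, known or untested is meant among the compounds shown, and "the series" means these compounds.

Working notes on the series. All compounds share one core and differ only in the group on the carbon with a double bond to nitrogen. Compound 1 `CN(C)CCn1cnnc1-c1cc(Oc2ccc(NC(=O)N/N=C/c3c(Cl)cccc3Cl)cc2F)ccn1` gives 160 nM in a functional assay on MKN-45 cells (Homo sapiens) for cytotoxicity, read by MTT assay, with a stated time of 72 h; on this read-out lower numbers stand for stronger inhibition and higher numbers for weaker inhibition. Compound 2 `CN(C)CCn1cnnc1-c1cc(Oc2ccc(NC(=O)N/N=C/c3ccc(O)c(Br)c3)cc2F)ccn1` gives 1860 nM in this assay, and compound 3 `CN(C)CCn1cnnc1-c1cc(Oc2ccc(NC(=O)N/N=C/c3ccccc3O[N+](=O)[O-])cc2F)ccn1` gives 1020 nM in this assay. Compound 3 therefore stands clearly apart from compound 1, a 6.4-fold higher number from compound 1 to compound 3 (0.80 log units; beyond the scatter), while its gap to compound 2 is within the scatter, a 1.8-fold lower number from compound 2 to compound 3 (0.26 log units; within the scatter). Compound 4 `CN(C)CCn1cnnc1-c1cc(Oc2ccc(NC(=O)N/N=C/c3ccc(F)cc3F)cc2F)ccn1` differs from compound 3 by 2,4-difluorophenyl in place of 2-(nitrooxy)phenyl on a carbon with a double bond to nitrogen. For the measured compounds named here, two measured steps bear on this change: the move from the halogen-bearing phenyl of compound 1 to the nitrooxyphenyl, a 6.4-fold higher number from compound 1 to compound 3 (0.80 log units; beyond the scatter), and the move to the bromo-hydroxyphenyl, a 12-fold higher number from compound 1 to compound 2 (1.07 log units; beyond the scatter). The entering group, like that of compound 1, carries only halogens and no hydrogen-bond donors or acceptors, so a return toward the number of compound 1 is expected in this assay, a lower number, though of uncertain size. Compound 4 is accordingly expected at about 320 nM, with a range of 120 nM to 900 nM, the expected step being a 3.2-fold lower number from compound 3 to compound 4 (0.50 log units; beyond the scatter).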

Compound 4, half-maximal inhibitory concentration: 810 nM
Estimate against measurement, compound 4: 2.5-fold (0.40 log units) below; measured number inside the range.
By their numbers in this assay, from the lowest: compound 1; then compounds 4, 3 and 2 (each within the scatter of the next, the first and the last beyond it).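

In this assay a phenyl bearing only halogens does not by itself reproduce the number of compound 1, and 2,4-difluorophenyl stands clearly apart from 2,6-dichlorophenyl at this position (a 5.1-fold higher number from compound 1 to compound 4 (0.70 log units; beyond the scatter)). Replacing 2-(nitrooxy)phenyl with 2,4-difluorophenyl removes the hydrogen-bond acceptors counted on the leaving group, yet the two compounds remain within the scatter of each other (a 1.3-fold lower number from compound 3 to compound 4 (0.10 log units; within the scatter)), while replacing 3-bromo-4-hydroxyphenyl with 2,4-difluorophenyl gives a modest step (a 2.3-fold lower number from compound 2 to compound 4 (0.36 log units; beyond the scatter)). No measurement is available that would explain these steps.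

The compounds shown do not separate the kind of halogen from its placing on the ring, a question that 2,6-difluorophenyl and 2,4-dichlorophenyl would address. From the compounds shown here alone, how a phenyl bearing an amine or a carboxylic acid would stand at this carbon also remains open.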